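Chain-length change in the shared core series

The source may hold more compounds than are shown below. What is called first, only, known or untested is meant among the compounds shown, and "the series" means these compounds.

Measured so far:
Compound 1 `COc1ccc(N(C)c2nc(C)nc3ccccc23)cc1OCCCCC[Se]C#N`: 4410 nM
Compound 2 `COc1ccc(N(C)c2nc(C)nc3ccccc23)cc1OCCCCCC[Se]C#N`: 3550 nM

In a functional assay on MDA-MB-231 cells (Homo sapiens) for inhibition, read by MTT assay, with a stated time of 48 h (on this read-out higher numbers stand for weaker inhibition and lower numbers for stronger inhibition), compound 2 holds the lowest of the two numbers; its nearest neighbour is compound 1, a gap within the scatter. Among the compounds with values here, the only measured step, a 1.2-fold lower number from compound 1 to compound 2 (0.09 log units; within the scatter), lengthens the chain by one carbon and stays within the scatter.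

Compound 3 `COc1ccc(N(C)c2nc(C)nc3ccccc23)cc1OCC[Se]C#N` differs from compound 2 by a group of 3 heavy atoms (1 carbon, 1 nitrogen, 1 selenium; no ring) in place of a group of 7 heavy atoms (5 carbon, 1 nitrogen, 1 selenium; no ring), on a saturated chain carbon, two bonds along the chain from an oxygen on an aromatic ring. Within the data shown here, this shortening is far larger than the one step seen, which bears on it only weakly; no step beyond the scatter is expected, direction uncertain. Compound 3 is therefore estimated at 5000 nM, range 2000 nM to 14000 nM, a step of a 1.4-fold higher number from compound 2 to compound 3 (0.15 log units; within the scatter).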

Compound 3, half-maximal inhibitory concentration: 13 nM
Beside the measured number, compound 3's estimate is 380-fold (2.59 log units) above it; measured number below the stated range.
By their numbers in this assay, from the lowest: compound 3; then compounds 2 and 1 (each within the scatter of the next).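

In this assay the response at this position is not flat with chain length, as the longer chains alone suggested: the shorter group, of 3 heavy atoms, gives a 270-fold lower number from compound 2 to compound 3 (2.44 log units; beyond the scatter) and also a 340-fold lower number from compound 1 to compound 3 (2.53 log units; beyond the scatter). Both steps lie beyond the scatter, whereas compound 1 and compound 2 lie within the scatter of each other. No measured evidence bears on this change. Still open is how a chain of intermediate length would read, since only these three lengths are shown. Also open, on these data alone, is whether a sulfur atom in place of the selenium would keep the low number of compound 3.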